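The source may report more compounds than this note shows. Statements on the series, on what has been measured and on what is new or still open speak of the compounds shown alone.

Compound 1 `ClCc1ccc(Cn2cnc3c(Cl)ncnc32)cc1` carries a chloromethyl-substituted benzyl group on a chlorinated purine-like core, and in a functional assay on HT-29 cells (Homo sapiens) for cytotoxicity, read by sulforhodamine B assay, with a stated time of 48 h (on this read-out higher numbers stand for weaker inhibition of growth and lower numbers for stronger inhibition of growth), its result is recorded only as "not determined" (no result reported), so it stands at no number on the scale here. Two related compounds give a sense of the range. Compound 2 `ClCc1cccc(Cn2cnc3c(Cl)nc(Cl)nc32)c1` gives a result in this assay that is a limit of the assay, > 100000 nM, not a measured number; this is the limit of > 100000 nM in this assay, at which 1 of the 3 values shown sits. Compound 3 `Nc1nc(Cl)c2ncn(Cc3ccccc3CCl)c2n1`, which carries an amino group and a chloromethyl group placed differently on the benzyl ring, gives 19100 nM in this assay.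

Compound 4 `Nc1nc(Cl)c2ncn(Cc3ccc(CCl)cc3)c2n1` differs from compound 1 by amino in place of hydrogen on an aromatic carbon. Going by the values given here, no measured pair shows this exact change, and with no number for compound 1 no step size in this assay can be stated; it is expected that compound 4 will sit near the weak end of growth inhibition, as compound 3 does with 19100 nM. Compound 4 is therefore estimated at 22000 nM, expected to fall between 5000 nM and 90000 nM.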

Compound 4, concentration for total growth inhibition: 27500 nM
Beside the measured number, compound 4's estimate is 1.3-fold (0.10 log units) below it; low and high end bracket the measured number.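

No step can be read from compound 1 to compound 4, as compound 1 has no number on this scale, and nothing shown accounts for the result of compound 4. On these data alone, what the amino group in place of hydrogen does to growth inhibition on this core stays open.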